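Oxazole-linked indole series: swapping the aryl for piperidine

A few compounds are considered here, and "the series" means these few. Any claim that something is new, unique, unknown or untested is made for them only; others in the source may bear on it.

Going by the values given here, compound 3 `Clc1ccc(-c2nc(-c3c[nH]c4ccccc34)co2)cc1` gives 505000 nM in a functional assay on LNCaP cells (Homo sapiens) for cytotoxicity, read by MTT assay, with a stated time of 48 h; a higher number here means a weaker inhibitor, a lower number a stronger inhibitor; this is the highest of the numbers measured so far, but the gaps to compound 1 `c1ccc(-c2nc(-c3c[nH]c4ccccc34)co2)cc1` at 461000 nM and to compound 2 `Cc1nc(-c2c[nH]c3ccccc23)co1` at 316000 nM are both within the scatter, so the three stand as one group. Compound 4 `c1ccc2c(-c3coc(C4CCNCC4)n3)c[nH]c2c1` carries piperidin-4-yl in place of 4-chlorophenyl on an aromatic carbon. Among the compounds with values here, the steps that bear on this position are a 1.5-fold lower number from compound 1 to compound 2 (0.16 log units; within the scatter) and a 1.6-fold higher number from compound 2 to compound 3 (0.20 log units; within the scatter), where the group on the same aromatic carbon moved between phenyl, methyl and 4-chlorophenyl without a step beyond the scatter; the step of a 1.1-fold higher number from compound 1 to compound 3 (0.04 log units; within the scatter) points the same way. Within the data shown here, no measured step covers a piperidin-4-yl group, so its own contribution is unknown. On the steps shown, the expectation for compound 4 in this assay is a step of a 1.2-fold lower number from compound 3 to compound 4 (0.08 log units; within the scatter), that is nothing beyond the scatter. The estimate for compound 4 is therefore 420000 nM, with a range of 150000 nM to 1200000 nM.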

Compound 4, half-maximal inhibitory concentration: 476000 nM
Beside the measured number, compound 4's estimate is 1.1-fold (0.05 log units) below it; the range from low to high includes it.
By their numbers in this assay, from the lowest: compounds 2, 1, 4 and 3 (each within the scatter of the next).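

At the aromatic carbon next to the ring nitrogen and next to the ring oxygen, replacing an aromatic ring of carbon only with the non-aromatic piperidin-4-yl ring gives no readable change in this assay. This holds against each earlier group (a 1.1-fold lower number from compound 3 to compound 4 (0.03 log units; within the scatter)) (a 1.5-fold higher number from compound 2 to compound 4 (0.18 log units; within the scatter)) (a 1.0-fold higher number from compound 1 to compound 4 (0.01 log units; within the scatter)). The earlier compounds covered only methyl, phenyl and 4-chlorophenyl here, whereas compounds 1 to 4 now show that a group with a ring nitrogen, a hydrogen-bond donor and a hydrogen-bond acceptor also leaves the series as one group, and no evidence on hand accounts for this.

From the compounds shown here alone, it remains open whether a carboxylic acid or a longer chain ending in an amine at this carbon would give a step beyond the scatter. Also open, going by these compounds, is whether a change elsewhere on the shared core would do so.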